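This account rests on a few compounds, and the source may have more. Where it says the series, first, only, none or still open, it means among the compounds named here.

Compound 1 `COc1cc2c(NCC3CCN(c4ncc(C(=O)NO)cn4)CC3)cc(-c3ccc(C)o3)nc2cc1OCCCN1CCCC1` gives 152 nM in an assay on isolated protein for inhibition of protein deacetylase HDAC6 (Homo sapiens), read by fluorescence, with a stated time of 30 min; a lower number here means a stronger inhibitor, a higher number a weaker inhibitor.
Compound 2 `COc1cc2c(NCC3CCN(c4ncc(C(=O)NO)cn4)CC3)cc(C)nc2cc1OCCCN1CCCC1` gives 350 nM in this assay.
Compound 3 `COc1cc2nc(-c3ccc(C)o3)cc(NCC3CCN(C4CC(C(=O)NO)C4)CC3)c2cc1OC` gives 3180 nM in this assay.

Among these three numbers compound 2 stands second highest: the step of a 2.3-fold higher number from compound 1 to compound 2 (0.36 log units; beyond the scatter) separates it from compound 1, and compound 3 sits well above it. Compound 4 `COc1cc2nc(C)cc(NCC3CCN(c4ncc(C(=O)NO)cn4)CC3)c2cc1OC` has not yet been measured. It differs from compound 2 in one place only: hydrogen in place of 2-(pyrrolidin-1-yl)ethyl on a saturated chain carbon bound to an oxygen on an aromatic ring. Going by the values given here, none of the measured steps touches this position, so there is no direct precedent. Compound 3 carries the same two methoxy groups that compound 4 would have, but it also differs from compound 1 in the part bearing the hydroxamic acid, so its much higher number cannot be assigned to the tail alone. Among the compounds with values here, the only measured step, from compound 1 to compound 2, changes a different site and was modest. On this basis the expected step of a 1.6-fold higher number from compound 2 to compound 4 (0.20 log units; within the scatter) is a modest move toward a higher number, possibly within the scatter. Compound 4 is therefore estimated at 550 nM, with a range from 200 nM to 1600 nM.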

Compound 4, half-maximal inhibitory concentration: 253 nM
Compound 4: the middle estimate sits 2.2-fold (0.34 log units) above what was measured; the measured number falls inside the stated range.
By their numbers in this assay, from the lowest: compounds 1, 4 and 2 (each within the scatter of the next, the first and the last beyond it); then compound 3.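

Replacing 3-(pyrrolidin-1-yl)propoxy with methoxy gives a 1.4-fold lower number from compound 2 to compound 4 (0.14 log units; within the scatter) in this assay. Going by these compounds alone, this is the first measured change at this position, and it shows that, with methyl on the shared core, the whole 2-(pyrrolidin-1-yl)ethyl part can be exchanged for hydrogen without a shift beyond the scatter. Nothing available explains why the number holds when this part is lost. The compounds shown leave open whether the same exchange would behave alike with 5-methylfuran-2-yl in place of that methyl. They also leave open whether a carboxylic acid, a primary amine or a longer chain ending in morpholine, placed on the same saturated chain carbon bound to an oxygen on an aromatic ring, would move the number beyond the scatter.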